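Cytotoxicity notes: trifluoromethyl to chloro on the aryl ring

This account rests on a few compounds, and the source may have more. Where it says the series, first, only, none or still open, it means among the compounds named here.

Measured so far:
compound 1 `C/C(=C\c1cc(-c2ccccc2)cs1)C(N)=O`: > 50000 nM
compound 2 `C/C(=C\c1cc(-c2ccc(C(F)(F)F)cc2)cs1)C(N)=O`: > 50000 nM

In an ADME assay on NIH3T3 cells (Mus musculus) for cytotoxicity, read by CCK-8 assay, with a stated time of 24 h (on this read-out lower numbers stand for stronger inhibition and higher numbers for weaker inhibition), compound 1 gives > 50000 nM, which is a limit of the assay and not a number. Compound 2 gives > 50000 nM in this assay, again a limit rather than a number. Among the compounds with values here, the one measured step, a step that the two limits leave unreadable from compound 1 to compound 2, brings trifluoromethyl in place of hydrogen on an aromatic carbon; its size cannot be read because both values sit at the limit of > 50000 nM in this assay, at which 2 of the 2 values shown sit. Compound 2 therefore stands at the limit, with no number to place it against.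

Compound 3 `C/C(=C\c1cc(-c2ccc(Cl)cc2)cs1)C(N)=O` differs from compound 2 by chloro in place of trifluoromethyl on an aromatic carbon. Only the unreadable step from compound 1 to compound 2 bears on this change, so no direction or size is set by the data. Compound 3 is expected to stay at the limit of this assay, estimated at 80000 nM with a range of 30000 nM to 300000 nM. The step from compound 2 to compound 3 is expected to be a step that the limit leaves unreadable from compound 2 to compound 3, nothing beyond the scatter.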

Compound 3, half-maximal inhibitory concentration: > 50000 nM
Compound 3 was reported as a limit; the forecaster's own chance of this, stated with the estimate: 85%; the middle value does not contradict the limit.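

No step among compound 1, compound 2 and compound 3 can be read, since each value is a limit and not a number: the limit of > 50000 nM in this assay, at which 3 of the 3 values shown sit.

The compounds shown leave open whether any substituent on the aryl ring gives a measurable value in this assay.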